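Removing a Nitro Group on Two Related Cores

The compounds below may be only part of what the source reports. "The series", "measured", "known", "first", "only" and "open" are said of these compounds alone.

In a functional assay for inhibition, read by spectrophotometry, with a stated time of 20 min, tested at 1 mg/mL (a higher number here means a stronger effect of the compound at the concentration tested, a lower number a weaker effect), compound 1 `CC(=O)c1ccc(NC(=O)CN(C(=O)c2ccccc2)S(=O)(=O)c2ccc([N+](=O)[O-])cc2)cc1` gives 20.6%.
In this assay compound 2 `CC(=O)c1ccc(NC(=O)C2CC(O)CN2S(=O)(=O)c2ccc([N+](=O)[O-])cc2)cc1` gives 43.2%.
In this assay compound 3 `CC(=O)c1ccc(NC(=O)CN(C(=O)c2ccccc2)S(=O)(=O)c2ccccc2)cc1` gives 40.5%.

Of the compounds shown here, three have been measured so far. Compound 1 and compound 3 share one core and differ in a single place: hydrogen in place of nitro on an aromatic carbon. That change moved the read-out in this assay by a number 19.9 percentage points higher from compound 1 to compound 3 (beyond the scatter). Compound 2 carries a different core; how its core differs from that of compound 1 is not broken down here. Compound 2 and compound 3 stand within the usual scatter of each other, so no order between them is claimed, while compound 2 stands clearly apart from compound 1.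

The fourth compound, compound 4 `CC(=O)c1ccc(NC(=O)C2CC(O)CN2S(=O)(=O)c2ccccc2)cc1`, has not yet been measured in this assay. It relates to compound 2 exactly as compound 3 relates to compound 1: hydrogen in place of nitro on an aromatic carbon. The two changes are the same kind of change, made on two different cores. Because compound 1 to compound 3 gave a number 19.9 percentage points higher from compound 1 to compound 3 (beyond the scatter), the same change on the core of compound 2 is expected to raise the read-out as well, though the cores are not the same and the step may come out smaller or larger. The step from compound 2 to compound 4 is therefore estimated at a number 11.8 percentage points higher from compound 2 to compound 4 (beyond the scatter). For compound 4 the expected read-out in this assay is 55%, with a likely range from 38% to 72%.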

Compound 4, a percentage reported as inhibition, at one concentration (the size of the read-out at that concentration, not a potency): 40.2%
Estimate against measurement, compound 4: 14.8 percentage points above; the measured number falls inside the stated range.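

In this assay, putting hydrogen in place of nitro on the core of compound 2 gives a number 3 percentage points lower from compound 2 to compound 4 (within the scatter), so on this core the two compounds cannot be told apart. The change from 4-nitrophenyl to phenyl therefore does not carry over at the same size from one core to the other, and the step seen on the first core cannot be used as a fixed increment for the second: the same change on two cores in this assay, a number 19.9 percentage points higher (beyond the scatter) from compound 1 to compound 3 and a number 3 percentage points lower (within the scatter) from compound 2 to compound 4, 22.9 percentage points apart, beyond the scatter of two such steps. This does not show why the two cores respond differently, since the cores differ in more than one place and each contributes a single pair, and it gives no rule for any further core; the read-outs also come from a single concentration, so they describe the size of the effect at that concentration and not a potency.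

The compounds shown hold only nitro or hydrogen at this place on the aromatic ring, so it remains open how an amine, a methoxy group or a chlorine atom there would read on either core. On these data alone, it also remains open whether a third core would follow the pair of compound 1 and compound 3 or the pair of compound 2 and compound 4.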